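The source may hold more compounds than are shown below. What is called first, only, known or untested is meant among the compounds shown, and "the series" means these compounds.

In a functional assay on the whole organism with Mus musculus as the target (a lower number here means that less compound is needed, a higher number that more compound is needed for the effect), compound 1 `CNc1c(C)c(C)c2c(c1C)CC(C)(C)O2` gives 16.6 mg/kg. Compound 2 `Cc1c(C)c2c(c(C)c1NS(C)(=O)=O)CC(C)(C)O2` gives > 100 mg/kg, which is a limit. Going by these compounds, compound 3 `Cc1c(C)c2c(c(C)c1Nc1ccc(Cl)cc1)CC(C)(C)O2` gives > 50 mg/kg, also a limit, so its true position remains unknown. Compound 4 `Cc1c(C)c2c(c(C)c1Nc1cccnc1)CC(C)(C)O2` has pyridin-3-yl in place of 4-chlorophenyl on a nitrogen on an aromatic ring. Two measured changes at this nitrogen bear on it: an at least 3.0-fold higher number from compound 1 to compound 3 (0.47 log units; beyond the scatter) and an at least 6.0-fold higher number from compound 1 to compound 2 (0.77 log units; beyond the scatter). Both lie beyond the scatter and show that replacing methyl raised the number. The change a step that the two limits leave unreadable from compound 2 to compound 3 cannot be read. Since compound 4 keeps an aromatic ring at this nitrogen, it is expected to stay close to compound 3, with no step beyond the scatter. The estimated step is a step that the limit leaves unreadable from compound 3 to compound 4. For compound 4, the estimated value is 60 mg/kg, within an expected range from 25 mg/kg to 150 mg/kg.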

Compound 4, dose for 50% inhibition: > 50 mg/kg
Compound 4: no number, only a limit (the forecaster's own chance of this, stated with the estimate: 55%); the middle value lies beyond the limit too.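

In this assay compound 4 gives > 50 mg/kg, which is a limit, and compound 3 and compound 4 stop at the same limit: the limit of > 50 mg/kg in this assay, at which 2 of the 4 values shown sit. Pyridin-3-yl in place of methyl gives an at least 3.0-fold higher number from compound 1 to compound 4 (0.47 log units; beyond the scatter), so a ring holding a nitrogen atom does not bring the number back towards compound 1, as 4-chlorophenyl did not. The steps linking compound 4 to compound 2 and to compound 3 cannot be read.

The order among these three groups stays open. Also open, going by these compounds, is whether a small group such as ethyl or acetyl on this nitrogen would stay close to compound 1.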